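The compounds below may be only part of what the source reports. "The series", "measured", "known", "first", "only" and "open" are said of these compounds alone.

Working notes on the series. Compound 1 `CCCC(CCC(=O)O)Cc1cccc(OCc2ccc3ccccc3n2)c1` is measured in a functional assay (lung) for inhibition, with Cavia porcellus as the target (on this read-out lower numbers stand for stronger inhibition and higher numbers for weaker inhibition), and gives 70 nM. Compound 2 `CCCC(CCc1nnn[nH]1)Cc1ccc(OCc2ccc3ccccc3n2)cc1` gives 32 nM and compound 3 `c1ccc2nc(COc3ccc(CCC4(Cc5nnn[nH]5)CCCC4)cc3)ccc2c1` gives 37 nM. Among these three numbers compound 1 stands highest; its gap to compound 3 lies within the scatter, its gap to compound 2 just beyond it.

Compound 4 `CC(CCc1nnn[nH]1)Cc1cccc(OCc2ccc3ccccc3n2)c1` differs from compound 1 in one place: 3-(1H-tetrazol-5-yl)-1-methylpropyl in place of 1-(2-carboxyethyl)butyl on a saturated chain carbon bound to an aromatic carbon. Among the compounds with values here, no measured pair shows this change directly. Compounds 2 and 3, which carry the same five-membered aromatic ring with 4 hetero atoms, both sit at lower numbers than compound 1, so a modest step toward stronger inhibition is expected, a 1.8-fold lower number from compound 1 to compound 4 (0.24 log units; within the scatter), not far beyond the scatter. Compound 4 is estimated at 40 nM, with a range from 15 nM to 110 nM.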

Compound 4, half-maximal inhibitory concentration: 150 nM
Beside the measured number, compound 4's estimate is 3.8-fold (0.57 log units) below it; measured number above the stated range.
By their numbers in this assay, from the lowest: compounds 2, 3 and 1 (each within the scatter of the next, the first and the last beyond it); then compound 4.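

In this assay, within the data shown here, placing 3-(1H-tetrazol-5-yl)-1-methylpropyl in place of 1-(2-carboxyethyl)butyl on a saturated chain carbon bound to an aromatic carbon gives a 2.1-fold higher number from compound 1 to compound 4 (0.33 log units; beyond the scatter), the first direct reading of this change, and it points toward weaker inhibition. The entering group differs from the leaving one at both its end group and its branch, so this single step cannot assign the loss to either. Nothing at hand accounts for the step.

Open, as far as these compounds go, is how a 3-carboxy-1-methylpropyl group would read at this place, keeping the carboxylic acid with the methyl branch. That reading would separate the two parts of the change.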